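Formyl and bromo variants on a shared core: cytotoxicity notes

The source may report more compounds than this note shows. Statements on the series, on what has been measured and on what is new or still open speak of the compounds shown alone.

Measured so far:
Compound 1 `O=c1oc2ccccc2cc1-c1cn2nc(Cc3ccc(Cl)cc3)sc2n1` gives in a functional assay on L1210 cells (Mus musculus) for cytotoxicity, with a stated time of 48 h (a higher number here means a weaker inhibitor, a lower number a stronger inhibitor), only a limit, > 10000 nM.
Compound 2 `Clc1ccc(Cc2nn3c(Br)c(-c4ccc(Cl)cc4)nc3s2)cc1` gives in this assay only a limit, > 250000 nM.
Compound 3 `O=Cc1c(-c2ccc(Cl)cc2)nc2sc(Cc3ccc(Cl)cc3)nn12` gives in this assay the number 15000 nM.

For the measured compounds named here, compound 3 thus stands as the only compound of the three with a real number in this assay; the other two values are limits of the assay. Going by the values given here, the one step between measured compounds is an at least 16-fold lower number from compound 2 to compound 3 (1.22 log units; beyond the scatter), which concerns the substituent on the core and not the chlorophenyl ring.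

Compound 4 `O=Cc1c(-c2ccccc2)nc2sc(Cc3ccc(Cl)cc3)nn12` differs from compound 3 by hydrogen in place of chloro on an aromatic carbon. No measured step touches this position, so nothing among the shown compounds bears on it directly. The step from compound 3 to compound 4 is therefore expected to stay within the scatter, a 1.3-fold higher number from compound 3 to compound 4 (0.12 log units; within the scatter). For compound 4 the estimate in this assay is 20000 nM, with a range from 6000 nM to 60000 nM.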

Compound 4, half-maximal inhibitory concentration: 20000 nM
Compound 4: the middle estimate sits on the measured number at the digits printed; the range from low to high includes it.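

For the compounds shown here, replacing 4-chlorophenyl with phenyl gives in this assay a 1.3-fold higher number from compound 3 to compound 4 (0.12 log units; within the scatter), the first reading at this position and the first step with a real number at both ends. With the formyl group held in place, the chloro on the six-membered aromatic ring can therefore give way to hydrogen without a change beyond the scatter. No measurement shown offers an explanation for this outcome.

Other groups at this position, such as a methoxy group, an amine or a carboxylic acid, remain open, so this single step sets no trend for the position. Also open, from the compounds shown here alone, is whether hydrogen in place of chloro reads the same when bromo takes the place of formyl on the shared core.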